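Benzylsulfanyl in Place of Methylsulfanyl on Two Cores

The source may hold more compounds than are shown below. What is called first, only, known or untested is meant among the compounds shown, and "the series" means these compounds.

Compound 1 `Cc1nnc(SCc2ccccc2)n1N1C(=O)c2ccccc2C1=O`: in a functional assay on MKN-45 cells (Homo sapiens) for cytotoxicity, read by MTT assay, with a stated time of 48 h (a lower number here means a stronger inhibitor, a higher number a weaker inhibitor), compound 1 reaches only the limit > 200000 nM.
Compound 2 `CSc1nnc(C)n1N1C(=O)c2ccccc2C1=O`: in this assay compound 2 reaches only the limit > 200000 nM.
Compound 3 `COc1cc(-c2nnc(SC)n2N2C(=O)c3ccccc3C2=O)cc(OC)c1OC`: in this assay compound 3 reaches only the limit > 200000 nM.

All three values are limits of this assay, not numbers. The change from compound 2 to compound 1 is phenyl in place of hydrogen on a saturated chain carbon bound to a sulfur; its step that the two limits leave unreadable from compound 2 to compound 1 cannot be read, since both ends sit at the limit of > 200000 nM in this assay, at which 3 of the 3 values shown sit. The difference between the core of compound 2 and the core of compound 3 is not broken down here. Compound 4 `COc1cc(-c2nnc(SCc3ccccc3)n2N2C(=O)c3ccccc3C2=O)cc(OC)c1OC` differs from compound 3 by phenyl in place of hydrogen on a saturated chain carbon bound to a sulfur, the same change that leads from compound 2 to compound 1. Within the data shown here, compound 4 is expected to show a step that the limit leaves unreadable from compound 3 to compound 4 that stays small because the only prior instance of this change left both compounds at the limit of > 200000 nM in this assay, at which 3 of the 3 values shown sit. Compound 4 is therefore expected to give about 300000 nM in this assay, most likely again only as a limit, with a range of 100000 nM to 1000000 nM.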

Compound 4, half-maximal inhibitory concentration: > 200000 nM
Compound 4: no number, only a limit; the forecaster's own chance of this, stated with the estimate: 85%; the middle value is on the limit's open side.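

Neither the step from compound 3 to compound 4 nor the step from compound 1 to compound 4 can be read, as all four compounds give a limit and not a number: the limit of > 200000 nM in this assay, at which 4 of the 4 values shown sit. The compounds shown leave open whether benzylsulfanyl in place of methylsulfanyl changes potency on either core, and which compound on these cores would give a measurable value.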